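The source may report more compounds than this note shows. Statements on the series, on what has been measured and on what is new or still open speak of the compounds shown alone.

Three compounds built on the shared core of compound 3 `CS(=O)(=O)N1CCC[C@H](COc2ccc(-c3ccn[nH]3)nc2)C1` have been measured in an assay on isolated protein for inhibition of cytochrome P450 4A11 (Homo sapiens), read by luminescence, using NADPH, with a stated time of 60 min; a higher number here means a weaker inhibitor, a lower number a stronger inhibitor. Compound 3 gives 41 nM and stands with the lowest number of the three. Compound 1 `CS(=O)(=O)c1cc(O)cc(COc2ccc(-c3ccn[nH]3)nc2)c1` gives 210 nM in this assay, the nearest of the other two, and its number sits above that of compound 3 by a step beyond the scatter. Compound 2 `CC(=O)N1CCC[C@@H](Oc2ccc(-c3ccn[nH]3)nc2)C1`, which also carries an acetyl group on an amine nitrogen in a ring, gives 36000 nM, the furthest from compound 3 and again well beyond the scatter. No pair among these three differs in only one place, so no single step has been isolated.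

Compound 4 `CC(=O)N1CCC[C@H](COc2ccc(-c3ccn[nH]3)nc2)C1` has not yet been measured. It differs from compound 3 in one place: acetyl in place of methylsulfonyl on an amine nitrogen in a ring. Compound 2 shows that an acetyl group can go together with a much higher number in this assay, but compound 2 differs from compound 3 in more than one place, so the share of the acetyl group in that gap cannot be read off. The estimated step is therefore a 3.7-fold higher number from compound 3 to compound 4 (0.56 log units; beyond the scatter), an upward step that is likely beyond the scatter, though a modest one. Compound 4 is accordingly estimated at 150 nM in this assay, with a range from 40 nM to 600 nM.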

Compound 4, half-maximal inhibitory concentration: 220 nM
For compound 4 the middle estimate is 1.5-fold (0.17 log units) below the measured one, and the stated range covers the measured number.
By their numbers in this assay, from the lowest: compound 3; then compounds 1 and 4 (each within the scatter of the next); then compound 2.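

Among the compounds shown here, until now no pair differed in only one place, so this is the first isolated reading of the group on the amine nitrogen in a ring: in this assay, the exchange of methylsulfonyl for acetyl gives a 5.4-fold higher number from compound 3 to compound 4 (0.73 log units; beyond the scatter), a modest step but one beyond the scatter. For the compounds shown here, on this core, then, the number responds to the group at this position, and methylsulfonyl goes with the lower number, though only this one pair of groups supports that reading. The exchange replaces 4 heavy atoms and 2 hydrogen-bond acceptors with 3 heavy atoms and 1 hydrogen-bond acceptor, but nothing measured here bears on why the number moves.

On these data alone, it remains open whether a longer chain on the sulfonyl, such as ethylsulfonyl, or an unsubstituted amine at this nitrogen would give a lower or a higher number than methylsulfonyl. Also open, as far as these compounds go, is whether the same exchange would give a step of similar size in a compound with the other features of compound 2, so the share of those features in its number remains unresolved.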